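A Furan-Bearing Urea Variant of a Weak Partial Agonist

A few compounds are considered here, and "the series" means these few. Any claim that something is new, unique, unknown or untested is made for them only; others in the source may bear on it.

Compound 1 `CCCCCNC(=O)/N=C(\N)NCCCc1sc(N)nc1C` is an acylguanidine in which a pentyl chain sits on the urea nitrogen. In a functional assay on HEK293T cells for agonist activity at histamine H2 receptor (Homo sapiens), read by beta-arrestin recruitment (a higher number here means a larger maximal response, a lower number a smaller maximal response), compound 1 gives 0.15, the lowest of the two numbers recorded. Within the data shown here, the only other number belongs to compound 2 `N/C(=N\C(=O)NCc1ccccc1)NC1CCc2nc(N)sc2C1`, whose ring-fused core differs from the shared core; in this assay compound 2 gives 0.31, a response that lies above that of compound 1 by more than the usual scatter. Compound 3 `CCCCCCNC(=O)/N=C(\N)Nc1cccc(-c2csc(N)n2)c1`, with a longer hexyl chain and a phenyl spacer, has no result: in this assay compound 3 gives "not determined" (no result reported), so nothing can be said of it.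

Compound 4 `Cc1nc(N)sc1CCCN/C(N)=N/C(=O)NC(C)c1ccco1` differs from compound 1 in one place: 1-(furan-2-yl)ethyl in place of pentyl on an amide-type nitrogen. Among the measured compounds shown here, no pair of measured compounds shows this exact change, so its effect cannot be read from the data. Given that compound 1 gives 0.15 in this assay and the change is at the outer edge of the molecule, the expected step a number 0.050 higher from compound 1 to compound 4 (within the scatter) is small and probably within the scatter, with a slight lean upward. For compound 4 the estimated maximal response in this assay is 0.2, in a range from 0.08 to 0.35.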

Compound 4, intrinsic activity: the largest response reached, as a fraction of the reference agonist's: 0.25
The estimate for compound 4 lay 0.050 below the measured number; the measured number falls inside the stated range.
By their numbers in this assay, from the lowest: compounds 1, 4 and 2 (each within the scatter of the next, the first and the last beyond it).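

In this assay, among these compounds, the step of a number 0.10 higher from compound 1 to compound 4 (within the scatter) is the first reading at this position, the amide-type nitrogen, and it gives no separation between the two compounds. Replacing the open pentyl chain with 1-(furan-2-yl)ethyl brings in a five-membered aromatic ring and a hydrogen-bond acceptor, yet the maximal response cannot be told apart from that of the parent compound, so this single swap gives no measurable gain or loss at this position. Nothing measured alongside these compounds bears on why the step has this size.

Among the compounds shown here, with only one step at this position, the data cannot separate any contribution of the furan ring from that of the branched carbon joining it to the nitrogen, and compounds 2 and 3 differ from compound 1 in more than one place, so they cannot settle the matter. Also open, from the compounds shown here alone, is how a furan-2-ylmethyl group, a cyclohexyl ring, a longer chain ending in a carboxylic acid or a chain ending in an amine would fare on this nitrogen, and whether any of them could move the response beyond the usual scatter.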